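Working notes: metabolic stability, compound 1 to compound 3

The source may hold more compounds than are shown below. What is called first, only, known or untested is meant among the compounds shown, and "the series" means these compounds.

Measured so far in an ADME assay on S9 fraction from liver (Rattus norvegicus) for metabolic stability, read by LC-MS, using NADPH, with a stated time of 30 min; on this read-out higher numbers stand for a more stable compound and lower numbers for a less stable compound:
compound 1 `CC(Oc1ccc(Oc2ccc(F)cc2)cc1)C(=O)Cn1nnc(-c2ccccc2)n1` gives < 5%
compound 2 `CC(Oc1ccc(-c2ccccc2)cc1)C(=O)Cn1nnc(-c2ccccc2)n1` gives < 5%

Compound 1 stands at the floor of this assay: its value of < 5% is a limit, not a number. Compound 2 is in the same position, its value of < 5% being likewise a limit. Among the compounds with values here, both values sit at the limit of < 5% in this assay, at which 2 of the 2 values shown sit, so the one step between compounds differing in a single place, a step that the two limits leave unreadable from compound 1 to compound 2, cannot be read in size or direction.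

Compound 3 `CC(Oc1ccc(Oc2ccc(F)cc2)cc1)C(=O)Cn1nnc(-c2ccc(Cl)cc2)n1` differs from compound 1 by chloro in place of hydrogen on an aromatic carbon, a chloro in place of hydrogen on an aromatic carbon, para to a large group; cut one bond further out this reads phenyl to 4-chlorophenyl. No measured step bears on this change: the only step shown concerns the 4-fluorophenoxy group and is itself unreadable.

With compound 1 at the limit and nothing to indicate a move upward, compound 3 is expected to stay at the limit, so a step that the limit leaves unreadable from compound 1 to compound 3 is estimated to lie within the scatter. Compound 3 is therefore expected to give 3%, in the range 0% to 10%, most likely reported once more as a limit.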

Compound 3, percent of the compound remaining: < 5%
Compound 3: no number, only a limit (the forecaster's own chance of this, stated with the estimate: 80%); the middle value is on the limit's open side.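

In this assay compound 3 gives < 5%, which is a limit and not a number, and compound 1 also stands at a limit, so no step between compound 1 and compound 3 can be read: the limit of < 5% in this assay, at which 3 of the 3 values shown sit.

The compounds shown leave open whether phenyl in place of 4-fluorophenoxy, or chloro in place of hydrogen, changes the read-out at all.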